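A Small Carbon Ring in Place of a Sulfur Tail

The source may hold more compounds than are shown below. What is called first, only, known or untested is meant among the compounds shown, and "the series" means these compounds.

Compound 1, `Cc1nc(S(C)(=O)=O)ccc1Oc1ncnc(OC2CCN(C(=O)OC(C)(C)C(F)(F)F)CC2)c1F`: in a functional assay on isolated protein for inhibition of Glucose-dependent insulinotropic receptor (Homo sapiens), read by HTRF and cAMP accumulation (a higher number here means that more compound is needed for the effect, a lower number that less compound is needed), compound 1 gives 6.53 nM.
Compound 2, `Cc1nc(S(C)(=O)=O)ccc1Oc1ncnc(OC2CCN(C(=O)O[C@@H](C)C(F)(F)F)CC2)c1F`: compound 2 gives 9.86 nM.
Compound 3, `Cc1nc(S(C)(=O)=O)ccc1Oc1ncnc(OC2CCN(C(=O)SC(C)C)CC2)c1F`: compound 3 gives 6.8 nM.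

All three compounds share one core and differ only in the group carried by a carbonyl carbon that sits on the ring nitrogen. Compound 3 stands second highest of the three numbers, yet this says little: its nearest neighbour is compound 1, a 1.0-fold higher number from compound 1 to compound 3 (0.02 log units; within the scatter), and its furthest is compound 2, a 1.5-fold lower number from compound 2 to compound 3 (0.16 log units; within the scatter). Every measured swap at this position has therefore stayed within the scatter.

Compound 4, `Cc1nc(S(C)(=O)=O)ccc1Oc1ncnc(OC2CCN(C(=O)C3(C)CC3)CC2)c1F`, changes the same position once more: 1-methylcyclopropyl in place of isopropylsulfanyl on a carbonyl carbon. This swap removes the sulfur link and brings in a small carbon ring, so it is not a close copy of the earlier swaps. Among the compounds with values here, still, the only guidance comes from compound 1 and compound 2, whose steps to compound 3 were a 1.0-fold higher number from compound 1 to compound 3 (0.02 log units; within the scatter) and a 1.5-fold lower number from compound 2 to compound 3 (0.16 log units; within the scatter), both small. Compound 4 is therefore expected to land close to compound 3, at about 7.5 nM, within a range of 3 nM to 20 nM. That estimate means an expected step of a 1.1-fold higher number from compound 3 to compound 4 (0.04 log units; within the scatter), with no direction favoured beyond the scatter.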

Compound 4, half-maximal effective concentration: 761 nM
Estimate against measurement, compound 4: 100-fold (2.01 log units) below; the measured number lies above the stated range.
By their numbers in this assay, from the lowest: compounds 1, 3 and 2 (each within the scatter of the next); then compound 4.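

In this assay, this position proves far less forgiving than compounds 1, 2 and 3 suggested, since swapping isopropylsulfanyl for 1-methylcyclopropyl gives a 110-fold higher number from compound 3 to compound 4 (2.05 log units; beyond the scatter) even though both groups count 4 heavy atoms, so that count does not separate them. The other two comparisons agree, with a 77-fold higher number from compound 2 to compound 4 (1.89 log units; beyond the scatter) and a 120-fold higher number from compound 1 to compound 4 (2.07 log units; beyond the scatter), and they point to a pattern among these four compounds with no exception: the three with an oxygen or sulfur atom on the carbonyl carbon need little compound, while the one with a carbon atom there needs much more. No measurement at hand gives a reason for this jump.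

The swap changes two things at once, the atom on the carbonyl carbon and the presence of a three-membered ring, and the compounds shown cannot pull these apart. A cyclopropoxy group would keep the ring with an oxygen on the carbonyl carbon, a tert-butyl group would keep a carbon there without the ring, and an amine in that place remains an open case as well.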